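The compounds below may be only part of what the source reports. "The series", "measured", "known", "first", "only" and "open" are said of these compounds alone.

Compound 1 `CC(C)Sc1nnc(-c2c(CNC3CC3)c3ccccc3n2C)n1-c1ccccc1`: 4.81 in a physicochemical assay for lipophilicity; a higher number here means a more lipophilic compound, a lower number a more polar compound
Compound 2 `CC(C)Sc1nnc(-c2c(CN3CCCCC3C)c3ccccc3n2C)n1-c1ccccc1`: 5.95 in this assay
Compound 3 `COc1ccc(CNCc2c(-c3nnc(SC(C)C)n3-c3ccccc3)n(C)c3ccc(F)cc23)cc1`: 6.42 in this assay

Compound 3 gives the highest of the three numbers, with compound 2 nearest and compound 1 furthest, both gaps beyond the scatter. Compound 4 `COCCNCc1c(-c2nnc(SC(C)C)n2-c2ccccc2)n(C)c2ccc(F)cc12` differs from compound 3 by methoxymethyl in place of 4-methoxyphenyl on a saturated chain carbon bound to an amine nitrogen. Among the compounds with values here, the only measured step, a number 1.14 log units higher from compound 1 to compound 2 (beyond the scatter), changes the amine itself rather than the group on the carbon bound to it, so it bears on the present change only loosely. Within the data shown here, no measured pair shows the loss of a six-membered aromatic ring of carbon only. The expected step is nonetheless a large fall, a number 1.82 log units lower from compound 3 to compound 4 (beyond the scatter). Compound 4 is estimated in this assay at 4.6, within 3.9 to 5.3.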

Compound 4, partition coefficient: 4.52
Compound 4: the middle estimate sits 0.08 log units above what was measured, within the range that was stated.
By their numbers in this assay, from the lowest: compounds 4 and 1 (each within the scatter of the next); then compound 2; then compound 3.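

In this assay, replacing 4-methoxyphenyl with methoxymethyl on a saturated chain carbon bound to an amine nitrogen gives a number 1.90 log units lower from compound 3 to compound 4 (beyond the scatter). Within the data shown here, this is the first measured step at this place, and it shows that the group carried there can move the number by a large amount. The change removes one six-membered aromatic ring of carbon only, while the counts of hydrogen-bond donors and acceptors stay the same, and nothing measured explains the fall. As far as these compounds go, it remains open whether an unsubstituted phenyl group or a longer chain such as 3-methoxypropyl would land nearer compound 3 or compound 4.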